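The compounds below may be only part of what the source reports. "The series", "measured", "known", "first", "only" and "open" are said of these compounds alone.

Compound 2 `O=C(Nc1ccnnc1)c1cc(N2CCC(F)CC2)ccc1OCc1ccccc1` gives 39.8 nM in an assay on Sf9 cells for inhibition of Leucine-rich repeat serine/threonine-protein kinase 2 (Homo sapiens), read by TR-FRET, with stated times of 30 min and 2 h; a lower number here means a stronger inhibitor, a higher number a weaker inhibitor. Within the data shown here, its number is the highest of the three measured so far, though the gap to compound 1 `O=C(Nc1cccc(F)c1)c1cc(C(F)(F)F)ccc1OCc1ccc(F)cc1`, which gives 31.6 nM, lies within the usual scatter, whereas compound 3 `N#Cc1cccc(NC(=O)c2cc(C(F)(F)F)ccc2OCc2ccc(F)cc2)c1`, which gives 7.94 nM, sits beyond it. Compound 4 `N#CC1CCN(c2ccc(OCc3ccccc3)c(C(=O)Nc3ccnnc3)c2)CC1` differs from compound 2 in one place: cyano in place of fluoro on a saturated ring carbon. Among the measured compounds shown here, the only measured step of a related kind is a 4.0-fold lower number from compound 1 to compound 3 (0.60 log units; beyond the scatter), where a cyano replaced a fluoro on an aromatic carbon. That swap took place on an aromatic ring rather than on a saturated ring carbon, so it bears only loosely on the change leading to compound 4. A gain smaller than that one, or none beyond the scatter, is therefore expected, and compound 4 is estimated at 25 nM with a likely range from 10 nM to 63 nM. This estimate corresponds to an expected step of a 1.6-fold lower number from compound 2 to compound 4 (0.20 log units; within the scatter).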

Compound 4, half-maximal inhibitory concentration: 10 nM
Compound 4: middle estimate off by 2.5-fold (0.40 log units), on the high side; low and high end bracket the measured number.
By their numbers in this assay, from the lowest: compounds 3 and 4 (each within the scatter of the next); then compounds 1 and 2 (each within the scatter of the next).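

Replacing 4-fluoropiperidin-1-yl with 4-cyanopiperidin-1-yl gives a 4.0-fold lower number from compound 2 to compound 4 (0.60 log units; beyond the scatter) in this assay and so shows that, in this series, the nitrile can lower the number from a saturated ring carbon as well as from an aromatic carbon. This step is printed at the same size as a 4.0-fold lower number from compound 1 to compound 3 (0.60 log units; beyond the scatter) even though the exchange sits at a different place on a different compound, but two pairs are too few to make a rule. No accompanying measurement bears on why the number falls in either pair.

As far as these compounds go, it remains open whether this gain is specific to the nitrile or would also appear with a hydroxyl, a methyl or a primary amide on the same ring carbon. A cyanomethyl group, which sets the nitrile on a longer chain, would test whether its distance from the ring matters.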